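The source may report more compounds than this note shows. Statements on the series, on what has been measured and on what is new or still open speak of the compounds shown alone.

Compound 1, with the structure `Cc1ccc(O)c(NCCCN2CCN(C(c3ccc(Cl)cc3)c3ccc(Cl)cc3)CC2)c1`, gives 0.48 ug/mL in a functional assay on the whole organism with Rattus norvegicus as the target; a higher number here means a weaker inhibitor, a lower number a stronger inhibitor. Compound 2, with the structure `Cc1ccc(O)c(N(CCCN2CCN(C(c3ccc(Cl)cc3)c3ccc(Cl)cc3)CC2)C(C)C)c1`, gives 2.2 ug/mL in this assay. The two are separated by a single change, (isopropyl in place of hydrogen on a nitrogen on an aromatic ring), and that change produced a step of a 4.6-fold higher number from compound 1 to compound 2 (0.66 log units; beyond the scatter).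

Compound 3, with the structure `Cc1ccc(O)c(NCCCN2CCN(C(c3ccc(F)cc3)c3ccc(F)cc3)CC2)c1`, gives 0.1 ug/mL in this assay, the lowest of the three numbers recorded. How the core of compound 3 differs from the core of compound 1 is not broken down here.

Compound 4, with the structure `Cc1ccc(O)c(N(CCCN2CCN(C(c3ccc(F)cc3)c3ccc(F)cc3)CC2)C(C)C)c1`, has not yet been measured. Within the data shown here, it differs from compound 3 by isopropyl in place of hydrogen on a nitrogen on an aromatic ring, the same change, at a place described in the same words, as the one that carried compound 1 to compound 2. On that basis the step from compound 3 to compound 4 is expected to be a 4.6-fold higher number from compound 3 to compound 4 (0.66 log units; beyond the scatter), resting on the step seen between compound 1 and compound 2, a 4.6-fold higher number from compound 1 to compound 2 (0.66 log units; beyond the scatter). Compound 4 is therefore estimated to give 0.46 ug/mL in this assay, with a likely range from 0.2 ug/mL to 1.1 ug/mL.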

Compound 4, half-maximal inhibitory concentration: 1.2 ug/mL
Beside the measured number, compound 4's estimate is 2.6-fold (0.42 log units) below it; the whole stated range lies below it.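

In this assay, isopropyl in place of hydrogen on a nitrogen on an aromatic ring again gave a higher number on the core of compound 3, with a step of a 12-fold higher number from compound 3 to compound 4 (1.08 log units; beyond the scatter). The two steps point the same way, and the gap between them cannot be told from ordinary measurement scatter: the same change on two cores in this assay, a 4.6-fold higher number (0.66 log units; beyond the scatter) from compound 1 to compound 2 and a 12-fold higher number (1.08 log units; beyond the scatter) from compound 3 to compound 4, 2.6-fold (0.42 log units) apart, within the scatter of two such steps. On these two cores the change therefore carried over in direction, with no difference in size that can be read, but two pairs do not show that it would behave the same way on any other core, and they give no reason for the higher number.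

The compounds shown leave open whether methyl, ethyl or cyclopropyl on that nitrogen would give a step like that of isopropyl. They also leave open how the change would read with bromine on the two outer rings, or with a longer chain leading to the piperazine.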